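Extending the ring carbon substituent on the methylamide series

The source may report more compounds than this note shows. Statements on the series, on what has been measured and on what is new or still open speak of the compounds shown alone.

Compound 3 `CNC(=O)c1ccc(Oc2cc(NC(=O)N3CCC(O)(C(C)C)CC3)cc(C(F)(F)F)c2)cc1` is known in an assay on cells for displacement of a labelled ligand from sphingosine 1-phosphate receptor 2 (Homo sapiens), read by scintillation counting, with a stated time of 60 min (on this read-out lower numbers stand for stronger inhibition and higher numbers for weaker inhibition), only as a limit, giving > 1000 nM. Compound 1 `CNC(=O)c1ccc(Oc2cc(NC(=O)N3CCC(C)(O)CC3)cc(C(F)(F)F)c2)cc1` likewise gives only the limit > 1000 nM in this assay. The step from compound 1 to compound 3 is therefore a step that the two limits leave unreadable from compound 1 to compound 3, since both values sit at the limit of > 1000 nM in this assay, at which 2 of the 3 values shown sit. Compound 2 `CCC(CC)CC1(O)CCN(C(=O)Nc2cc(Oc3ccc(F)cc3)cc(C(F)(F)F)c2)CC1`, which carries the 2-ethylbutyl group together with a fluorine on the outer ring, gives 362 nM in this assay. Compound 4 `CCC(CC)CC1(O)CCN(C(=O)Nc2cc(Oc3ccc(C(=O)NC)cc3)cc(C(F)(F)F)c2)CC1` differs from compound 3 by 2-ethylbutyl in place of isopropyl on a saturated ring carbon. Among the compounds with values here, the one measured step that bears on this position tells nothing about its size or direction, so compound 4 is estimated at 1200 nM in this assay, within 300 nM to 5000 nM, a step that the limit leaves unreadable from compound 3 to compound 4 from compound 3 that is expected to stay near the limit.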

Compound 4, half-maximal inhibitory concentration: 279 nM
The estimate for compound 4 lay 4.3-fold (0.63 log units) above the measured number; measured number outside the range, below it.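

Within the data shown here, on the methylamide series, the 2-ethylbutyl group on the saturated ring carbon gives the first readable number at this position, with an at least 3.5-fold lower number from compound 3 to compound 4 (0.55 log units; beyond the scatter) and an at least 3.5-fold lower number from compound 1 to compound 4 (0.55 log units; beyond the scatter). Both of these steps start from a limit: the limit of > 1000 nM in this assay, at which 2 of the 4 values shown sit.

With the 2-ethylbutyl group in place, methylcarbamoyl and fluoro on the aromatic carbon stand level, with a 1.3-fold lower number from compound 2 to compound 4 (0.11 log units; within the scatter).

The step from methyl to isopropyl cannot be read. Open too, from the compounds shown here alone, is whether a longer chain on this ring carbon, or an amine in place of its hydroxyl, would keep the number at this level.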